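Pyrazole substituent swap in the aminopyrimidine nitrile series

This account rests on a few compounds, and the source may have more. Where it says the series, first, only, none or still open, it means among the compounds named here.

Going by the values given here, compound 2 `C[C@@H]1CCCN1c1c(C#N)c2c(N)nc(Nc3cnn(C)c3)nc2n1C` stands at the lowest of the two numbers so far in an assay on isolated protein for binding affinity to Leucine-rich repeat serine/threonine-protein kinase 2 (Homo sapiens), read by TR-FRET and LanthaScreen, with a stated time of 2 h (on this read-out lower numbers stand for stronger inhibition and higher numbers for weaker inhibition), where compound 2 gives 0.1 nM. Its nearest neighbour is compound 1 `C[C@@H]1CCCN1c1c(C#N)c2c(N)nc(Nc3cn[nH]c3)nc2n1C`, which in this assay gives 0.2 nM; the step of a 2.0-fold lower number from compound 1 to compound 2 (0.30 log units; within the scatter) lies within the scatter. Compound 3 `Cc1n[nH]cc1Nc1nc(N)c2c(C#N)c(N3CCC[C@H]3C)n(C)c2n1` is not yet measured and carries 3-methyl-1H-pyrazol-4-yl in place of 1-methyl-1H-pyrazol-4-yl on a nitrogen on an aromatic ring. Among the compounds with values here, the only measured step that bears on this change is the addition of the methyl on an aromatic nitrogen from compound 1 to compound 2, which was within the scatter; nothing measured speaks to a methyl on ring carbon, so no step beyond the scatter is expected in this assay for this change. For compound 3 in this assay the expected value is 0.2 nM, within 0.05 nM to 0.8 nM. The expected step of a 2.0-fold higher number from compound 2 to compound 3 (0.30 log units; within the scatter) is therefore taken to lie within the scatter.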

Compound 3, inhibition constant: 1 nM
Estimate against measurement, compound 3: 5.0-fold (0.70 log units) below, and the stated range ends below it.
By their numbers in this assay, from the lowest: compounds 2 and 1 (each within the scatter of the next); then compound 3.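

In this assay this position proves sensitive to where the methyl sits: 3-methyl-1H-pyrazol-4-yl in place of 1-methyl-1H-pyrazol-4-yl gives a 10-fold higher number from compound 2 to compound 3 (1.00 log units; beyond the scatter), even though the two groups have the same atoms. Methyl in place of hydrogen on an aromatic carbon gives a 5.0-fold higher number from compound 1 to compound 3 (0.70 log units; beyond the scatter), so a methyl on the pyrazole now produces a step beyond the scatter, which the methyl on the aromatic nitrogen did not. Nothing available accounts for this difference between the two methyl placements.

From the compounds shown here alone, whether the step is particular to methyl remains open, since an ethyl, a methoxy or an amine on the same ring carbon could give a different result. Also open, going by these compounds, is how a pyrazole carrying methyl on both the aromatic nitrogen and the ring carbon would read.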